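The compounds below may be only part of what the source reports. "The series", "measured", "known", "first", "only" and "open" are said of these compounds alone.

Compound 1 `Nc1scc(CN2CCN(c3ccc(OC(F)(F)F)cc3)CC2)c1C(=O)c1ccc(Cl)cc1` gives the lowest of the two numbers in hand: in a functional assay on CHO cells with adenosine receptor A1 (Homo sapiens) as the target, read by cAMP accumulation and immunoassay, with a stated time of 6 min, tested at 10 uM (a lower number here means a stronger effect, a higher number a weaker effect of the compound at the concentration tested), compound 1 gives -74%. Compound 2 `Nc1scc(CN2CCN(c3c(F)cccc3F)CC2)c1C(=O)c1cccc(C(F)(F)F)c1`, which differs from it in several positions, gives 4% in this assay, a gap well beyond the scatter. Compound 3 `Nc1scc(CN2CCN(CCCc3ccc(Cl)cc3)CC2)c1C(=O)c1ccc(Cl)cc1` differs from compound 1 in this assay by 3-(4-chlorophenyl)propyl in place of 4-(trifluoromethoxy)phenyl on an amine nitrogen in a ring. Going by the values given here, no measured pair shows this change alone, so the expected step is uncertain; a weakening beyond the scatter, toward a higher number, is expected, as a number 34 percentage points higher from compound 1 to compound 3 (beyond the scatter). Compound 3 is estimated at -40%, within -85% to 15%.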

Compound 3, a percentage reported as activity, at one concentration (the size of the read-out at that concentration, not a potency): -76%
The estimate for compound 3 lay 36 percentage points above the measured number, and the stated range covers the measured number.
By their numbers in this assay, from the lowest: compounds 3 and 1 (each within the scatter of the next); then compound 2.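

In this assay, the amine nitrogen in the ring accepts 3-(4-chlorophenyl)propyl in place of 4-(trifluoromethoxy)phenyl with no loss of effect, as a number 2 percentage points lower from compound 1 to compound 3 (within the scatter) shows. Going by these compounds alone, compounds 1 and 2 both carry a phenyl ring on this nitrogen, so compound 3 is the first sign that a propyl chain can stand there. No measurement in hand accounts for this result.

As far as these compounds go, the chain and the ring substituent change together in this step, so their separate contributions remain unknown. From the compounds shown here alone, how a benzyl group, or a propyl chain ending in an amine or a carboxylic acid, would read here is also open.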